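Swapping Bromophenyl for Hydroxy-Methylphenyl: Expected Edema Inhibition

This account rests on a few compounds, and the source may have more. Where it says the series, first, only, none or still open, it means among the compounds named here.

Of the compounds shown here, three sharing one core have been tested in a functional assay on the whole organism (strain Wistar) for inhibition, with Rattus norvegicus as the target, read by paw edema, with stated times of 30 min and 5 h, at a dose of 0.05 mmol/kg by the oral route; on this read-out lower numbers stand for less inhibition and higher numbers for more inhibition at the one dose given (going by the name of the read-out). Compound 1 `Cc1cc(C2=NN(c3ccc(S(C)(=O)=O)cc3)C(=O)CC2)ccc1O` gives 60.5%, compound 2 `CCc1ccc(C2=NN(c3ccc(S(C)(=O)=O)cc3)C(=O)CC2)cc1` gives 65.7%, and compound 3 `CS(=O)(=O)c1ccc(N2N=C(c3ccc(Br)cc3)CCC2=O)cc1` gives 31.5%. Compound 3 stands lowest of the three: the steps are a number 29 percentage points lower from compound 1 to compound 3 (beyond the scatter) and a number 34.2 percentage points lower from compound 2 to compound 3 (beyond the scatter), both beyond the scatter, whereas a number 5.2 percentage points higher from compound 1 to compound 2 (within the scatter).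

Compound 4 `Cc1ccc(O)c(C2=NN(c3ccc(S(C)(=O)=O)cc3)C(=O)CC2)c1` has not yet been measured in this assay. It differs from compound 3 in this way: 2-hydroxy-5-methylphenyl in place of 4-bromophenyl on a carbon with a double bond to nitrogen. The entering group carries the same hydroxyl and methyl as the group on compound 1, arranged differently on the ring. Among the compounds with values here, the one measured step that bears on this change is a number 29 percentage points lower from compound 1 to compound 3 (beyond the scatter), read in reverse; putting a hydroxy-methylphenyl back in place of the bromophenyl should undo much of that drop. In this assay compound 4 is expected to give about 54%, within a range from 36% to 70%. This corresponds to an expected step of a number 22.5 percentage points higher from compound 3 to compound 4 (beyond the scatter). Within the data shown here, the range is kept wide since the arrangement of the hydroxyl and methyl is not the one seen in compound 1.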

Compound 4, a percentage reported as inhibition, in the whole organism at one dose (the size of the read-out at that dose, not a potency): 86.8%
For compound 4 the middle estimate is 32.8 percentage points below the measured one; the whole stated range lies below it.
By their numbers in this assay, from the lowest: compound 3; then compounds 1 and 2 (each within the scatter of the next); then compound 4.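

Within the data shown here, putting 2-hydroxy-5-methylphenyl in place of 4-bromophenyl gives a number 55.3 percentage points higher from compound 3 to compound 4 (beyond the scatter) and shows that this position can carry far more than the earlier compounds reached, since the same group also gives a number 21.1 percentage points higher from compound 2 to compound 4 (beyond the scatter) against 4-ethylphenyl. Compound 1 and compound 4 carry the same hydroxyl and methyl on the phenyl ring, yet moving to the arrangement in compound 4 gives a number 26.3 percentage points higher from compound 1 to compound 4 (beyond the scatter) in this assay so the arrangement of these two groups counts here, not just their presence. Nothing measured here accounts for why this arrangement gives the higher number.

On these data alone, what stays open is how much of the gain belongs to the hydroxyl and how much to the methyl, which a plain 2-hydroxyphenyl group would help to separate. As far as these compounds go, it is also open whether a methoxy group or an amine in place of that hydroxyl would keep the number as high.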